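Nonyl to 2-amino-1-hydroxyethyl on the chain carbon

This account rests on a few compounds, and the source may have more. Where it says the series, first, only, none or still open, it means among the compounds named here.

Compound 3 `CCCCCCCCCCn1c(=O)n(C2OC(CO)[C@@H](O)[C@H]2O)c2nc(N)nc(O)c21` gives 0% in a functional assay on the whole organism (B cells) with Mus musculus as the target (on this read-out lower numbers stand for smaller maximal responses and higher numbers for larger maximal responses), the lowest of the three numbers: compound 2 `Nc1nc(O)c2c(n1)n(C1OC(CO)[C@@H](O)[C@H]1O)c(=O)n2Cc1ccc(Cl)cc1` gives 15%, and compound 1 `CCOC(=O)Cn1c(=O)n(C2OC(CO)[C@@H](O)[C@H]2O)c2nc(N)nc(O)c21` gives 86%. Compound 4 `NCC(O)Cn1c(=O)n(C2OC(CO)[C@@H](O)[C@H]2O)c2nc(N)nc(O)c21` differs from compound 3 by 2-amino-1-hydroxyethyl in place of nonyl on a saturated chain carbon bound to an aromatic nitrogen. For the measured compounds named here, the steps that bear on it are the ones that put the nonyl in place: a number 86 percentage points lower from compound 1 to compound 3 (beyond the scatter) and a number 15 percentage points lower from compound 2 to compound 3 (beyond the scatter). Since the nonyl now leaves again and a short chain enters, as in compound 1, a large rise in this assay is expected, a number 75 percentage points higher from compound 3 to compound 4 (beyond the scatter). Compound 4 is therefore expected to give about 75%, within 40% to 100%.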

Compound 4, largest response reached (reported as maximal response), in percent of the reference or control that the assay uses: 110%
For compound 4 the middle estimate is 35 percentage points below the measured one; measured number outside the range, above it.
By their numbers in this assay, from the lowest: compound 3; then compound 2; then compound 1; then compound 4.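

On the saturated chain carbon bound to an aromatic nitrogen, 2-amino-1-hydroxyethyl gives the highest number of the four compounds in this assay: a number 110 percentage points higher from compound 3 to compound 4 (beyond the scatter) and a number 95 percentage points higher from compound 2 to compound 4 (beyond the scatter). It also exceeds ethoxycarbonyl, a number 24 percentage points higher from compound 1 to compound 4 (beyond the scatter), so the response at this position depends on more than replacing nonyl or 4-chlorophenyl with ethoxycarbonyl or 2-amino-1-hydroxyethyl. Nothing available gives a cause for these steps.

Open, as far as these compounds go, is whether the amine or the hydroxyl in this group accounts for the rise. Also open, from the compounds shown here alone, is how a carboxylic acid or a longer aminoalkyl chain would read at this position.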